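A few compounds are considered here, and "the series" means these few. Any claim that something is new, unique, unknown or untested is made for them only; others in the source may bear on it.

Measured in an in vitro ADME assay on microsomes from Gut (Homo sapiens) for metabolic stability, in the presence of a further agent that is not named here; a higher number here means faster removal of the compound, a lower number slower removal:
- Compound 1 `CCOc1ccc(OC(F)(F)F)cc1Cn1c(C(=O)NCC(C)(C)CO)cc2cc(C#N)ccc21`: 103 mL.min-1.g-1
- Compound 2 `CC(C)(CO)CNC(=O)c1cc2cc(C#N)ccc2n1Cc1cc(Cl)cc(Cl)c1`: 98 mL.min-1.g-1
- Compound 3 `COc1ccc(Cl)cc1Cn1c(C(=O)NCC(C)(C)CO)cc2cc(C#N)ccc21`: 63 mL.min-1.g-1

These three compounds share a core and differ in the groups on one aromatic ring. Compound 3, at 63 mL.min-1.g-1, lies within the usual scatter of both other compounds, so the three numbers cannot be told apart with confidence.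

The next compound is compound 4 `COc1ccc(C)cc1Cn1c(C(=O)NCC(C)(C)CO)cc2cc(C#N)ccc21`. It differs from compound 3 by one small exchange, methyl in place of chloro on an aromatic carbon, para to a methoxy group.

Among the measured compounds shown here, no measured pair shows this exact exchange. The closest evidence is a 1.6-fold lower number from compound 2 to compound 3 (0.19 log units; within the scatter), a change on the same ring that stays within the scatter. That step alters more of the ring than the exchange in compound 4 does, yet it gives no measurable shift. This is a single step, so it offers only modest support, and it gives no direction for a methyl group.

The expected result is therefore no change beyond the scatter, with a 1.1-fold higher number from compound 3 to compound 4 (0.05 log units; within the scatter) as the estimated step. The estimated value for compound 4 is 70 mL.min-1.g-1, with an expected range from 35 mL.min-1.g-1 to 135 mL.min-1.g-1.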

Compound 4, intrinsic clearance in microsomes: 64 mL.min-1.g-1
Compound 4: middle estimate off by 1.1-fold (0.04 log units), on the high side; the range from low to high includes it.
By their numbers in this assay, from the lowest: compounds 3, 4, 2 and 1 (each within the scatter of the next).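

In this assay, among the compounds shown here, the exchange of chloro for methyl on this aromatic carbon, para to a methoxy group, gives a 1.0-fold higher number from compound 3 to compound 4 (0.01 log units; within the scatter), the first direct reading of a change at this one place, and it shows that the two groups cannot be told apart here. The larger exchange, 2-methoxy-5-methylphenyl in place of 3,5-dichlorophenyl, gives a 1.5-fold lower number from compound 2 to compound 4 (0.19 log units; within the scatter), so this methyl-bearing ring also shows no clear shift, just as the chloro-bearing ring of compound 3 did. Nothing measured here bears on why chloro and methyl read alike at this carbon.

Chloro and methyl each count only one heavy atom, so it stays open whether a group of a different kind at this carbon, such as an amine, a carboxylic acid or a longer chain, would move the number beyond the scatter. The nitrile and the hydroxyl-bearing amide chain are the same in all four compounds, so what a change at either of those places would do is also unknown.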